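Aryl swap on the saturated ring carbon: half-life outlook

This account rests on a few compounds, and the source may have more. Where it says the series, first, only, none or still open, it means among the compounds named here.

The measured compounds, with their results in an in vivo ADME assay on the whole organism for metabolic stability, with Rattus norvegicus as the target, using cassette dosing; a lower number here means that the compound disappears faster, a higher number that the compound lasts longer:
- compound 1, `CC[C@@]1(O)C[C@H](C(=O)Nc2ccc(-n3ccccc3=O)cc2F)N(C(=O)Nc2ccc(Cl)cc2)C1`, gives 2.4 h
- compound 2, `CCO[C@]1(CC)C[C@H](C(=O)Nc2ccc(-n3ccccc3=O)cc2F)N(C(=O)Nc2ccc(Cl)cc2)C1`, gives 1.4 h
- compound 3, `Cc1cccc([C@@]2(O)C[C@H](C(=O)Nc3ccc(-n4ccccc4=O)cn3)N(C(=O)Nc3ccc(Cl)cc3)C2)c1`, gives 1.4 h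

Compound 3 sits level with compound 2 at the digits reported, and these two share the lowest number of the three; its gap to compound 1 is within the scatter, so no order among the three can be drawn in this assay. Among the measured compounds shown here, the one step between measured compounds that differ in a single place, a 1.7-fold lower number from compound 1 to compound 2 (0.23 log units; within the scatter), concerns an ethyl group on an oxygen and stays within the scatter.

Compound 4, `O=C(Nc1ccc(-n2ccccc2=O)cn1)[C@H]1C[C@](O)(c2ccc(F)c(F)c2)CN1C(=O)Nc1ccc(Cl)cc1`, has not yet been measured in this assay. It differs from compound 3 in one place: 3,4-difluorophenyl in place of 3-methylphenyl on a saturated ring carbon. For the measured compounds named here, no measured pair bears on an exchange of one aromatic ring for another at this position; the only step available, the ethylation from compound 1 to compound 2, lies elsewhere and was small. With nothing in the data pointing in either direction, the expectation for compound 4 is a number close to that of compound 3, and the step of no change at the digits printed from compound 3 to compound 4 (within the scatter) is expected to stay within the scatter. Compound 4 is therefore estimated at 1.4 h, with a range from 0.7 h to 3 h.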

Compound 4, half-life: 2.1 h
Beside the measured number, compound 4's estimate is 1.5-fold (0.18 log units) below it; low and high end bracket the measured number.
By their numbers in this assay, from the lowest: compounds 2, 3, 4 and 1 (each within the scatter of the next).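

In this assay, the first step read at this position, a 1.5-fold higher number from compound 3 to compound 4 (0.18 log units; within the scatter), comes from 3,4-difluorophenyl taking the place of 3-methylphenyl on the saturated ring carbon, two ring bonds from the ring nitrogen. The exchange replaces a ring with one methyl group by a ring with two fluorine atoms, while the six-membered aromatic ring of carbon, the absence of hydrogen-bond donors and acceptors in the group and the absence of net charge all stay the same, and with a step of this size the half-life does not separate these two aryl groups. Nothing available explains the small step, and no supporting measurement bears on it.

This single pair cannot show whether the result extends to aryl groups of another kind at this carbon, such as a phenyl ring carrying an amine, a carboxylic acid or a methoxy group. It also leaves open whether a longer alkyl chain in place of the aromatic ring, on the same saturated ring carbon, would give a step beyond the scatter.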